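Swapping the ring on the chain of compound 1

This account rests on a few compounds, and the source may have more. Where it says the series, first, only, none or still open, it means among the compounds named here.

In an in vitro ADME assay on microsomes from liver (Simiiformes) (a higher number here means that the compound lasts longer, a lower number that the compound disappears faster), compound 1 `CCc1cc(CCCOc2c(C)cc(-c3noc(C)n3)cc2C)on1` gives 0.183 h, the lowest of three numbers, against compound 2 `CCc1cc(CCCOc2c(C)cc(-c3noc(C4CC4)n3)cc2C)on1` at 0.9 h and compound 3 `Cc1cc(CCCOc2c(C)cc(-c3noc(C(C)(F)F)n3)cc2C)on1` at 1.1 h. Compound 4 `Cc1ccc(CCCOc2c(C)cc(-c3noc(C)n3)cc2C)cn1` differs from compound 1 at one place: 6-methylpyridin-3-yl in place of 3-ethyl-1,2-oxazol-5-yl on a saturated chain carbon, three bonds along the chain from an oxygen on an aromatic ring. There, 6-methylpyridin-3-yl stands in place of 3-ethyl-1,2-oxazol-5-yl on a saturated chain carbon. Going by the values given here, the only measured single change is a 4.9-fold higher number from compound 1 to compound 2 (0.69 log units; beyond the scatter), with cyclopropyl in place of methyl on an aromatic carbon. Among the compounds with values here, it concerns a different group, so no measured step covers this swap, and the data give no clear direction. The estimated change is a 1.4-fold higher number from compound 1 to compound 4 (0.14 log units; within the scatter), so no step beyond the scatter is expected. Compound 4 is expected at 0.25 h, within a range of 0.1 h to 0.7 h.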

Compound 4, half-life: 1.37 h
For compound 4 the middle estimate is 5.5-fold (0.74 log units) below the measured one, and the stated range ends below it.
By their numbers in this assay, from the lowest: compound 1; then compounds 2, 3 and 4 (each within the scatter of the next).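

In this assay the ring at the end of the chain clearly matters: 6-methylpyridin-3-yl in place of 3-ethyl-1,2-oxazol-5-yl gives a 7.5-fold higher number from compound 1 to compound 4 (0.87 log units; beyond the scatter) with the same count of heavy atoms. Going by these compounds alone, the earlier step changed only a group on an aromatic carbon, so this is the first sign that the saturated chain carbon's ring substituent also moves this number. No measured evidence here explains the change.
Going by these compounds, whether a plain phenyl ring at this place would give a similar number remains open. So does whether 6-methylpyridin-3-yl would raise the number when cyclopropyl replaces the methyl, as in compound 2.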